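Replacing a methyl with hydrogen on compound 2

This account rests on a few compounds, and the source may have more. Where it says the series, first, only, none or still open, it means among the compounds named here.

In a functional assay for inhibition (on this read-out higher numbers stand for weaker inhibition and lower numbers for stronger inhibition), compound 1 (`CC(C)(C)c1cc(-c2cc(=O)c3ccc(OCCCS(=O)(=O)O)cc3o2)cc(C(C)(C)C)c1O`) gives 500 nM. Compound 2 (`COc1ccc2c(=O)cc(-c3cc(C(C)(C)C)c(OC)c(C(C)(C)C)c3)oc2c1`) stands at > 100000 nM, which is a limit of the assay and not a number. Compound 3 (`COc1ccc2c(=O)cc(-c3cc(C(C)(C)C)c(O)c(C(C)(C)C)c3)oc2c1`) has hydrogen in place of methyl on an oxygen on an aromatic ring, a change of methoxy to hydroxy (hydrogen in place of methyl on an oxygen on an aromatic ring). The expected change is a large one toward stronger inhibition, well beyond the usual scatter, and an at least 33-fold lower number from compound 2 to compound 3 (1.52 log units; beyond the scatter) is the estimated step. This expectation rests on compound 1, whose 500 nM is a measured number and not a limit. For compound 3 the estimate is 3000 nM, with an expected range of 300 nM to 30000 nM.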

Compound 3, half-maximal inhibitory concentration: 1000 nM
Beside the measured number, compound 3's estimate is 3.0-fold (0.48 log units) above it; measured number inside the range.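

Going from methoxy to hydroxy on the aromatic ring gives an at least 100-fold lower number from compound 2 to compound 3 (2.00 log units; beyond the scatter), so in this pair, read in this assay, inhibition appears only with the free hydroxy. Compound 2 stands at a limit of the assay and not a number, so the full size of this step stays unknown: the limit of > 100000 nM in this assay, at which 1 of the 3 values shown sits.

Hydrogen in place of 2-sulfoethyl gives a 2.0-fold higher number from compound 1 to compound 3 (0.30 log units; within the scatter), so that chain is not required for this level of inhibition.

From the compounds shown here alone, whether a small group such as acetyl on the same oxygen would keep inhibition remains open. So does the effect of a carboxylic acid or an amine at the end of the chain.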